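Adding a methyl to the phenyl of compound 3

The compounds below may be only part of what the source reports. "The series", "measured", "known", "first", "only" and "open" are said of these compounds alone.

In an assay on HEK293 cells for displacement of a labelled ligand from metabotropic glutamate receptor 5 (Homo sapiens), with a stated time of 2 h (a higher number here means a weaker inhibitor, a lower number a stronger inhibitor), compound 3 `CC(C)N1CCc2nc(C#Cc3ccccc3)ccc2C1=O` gives 1280 nM, the second highest of the three numbers measured. Compound 1 `Cc1cccc(C#Cc2ccc3c(n2)CCN(C)C3=O)c1` gives 820 nM in this assay, a gap to compound 3 that stays within the scatter; compound 2 `CN1CCc2nc(C#Cc3cccnc3)ccc2C1=O` gives 27400 nM, far beyond it. For the measured compounds named here, the one single-point step measured, a 33-fold higher number from compound 1 to compound 2 (1.52 log units; beyond the scatter), concerns an exchange of the whole aromatic ring on the triple-bonded carbon and does not touch the change now considered. Compound 4 `Cc1cccc(C#Cc2ccc3c(n2)CCN(C(C)C)C3=O)c1` differs from compound 3 by methyl in place of hydrogen on an aromatic carbon. Going by the values given here, no measured pair isolates this change: compound 1 and compound 3 differ in two places at once, and their values in this assay lie within the scatter of each other. On that basis the step of a 1.4-fold lower number from compound 3 to compound 4 (0.15 log units; within the scatter) is expected to be small, if anything toward a lower number, but not clearly beyond the scatter. Compound 4 is therefore estimated at 900 nM in this assay, with a range from 400 nM to 2500 nM.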

Compound 4, inhibition constant: 510 nM
Beside the measured number, compound 4's estimate is 1.8-fold (0.25 log units) above it, and the stated range covers the measured number.
By their numbers in this assay, from the lowest: compounds 4, 1 and 3 (each within the scatter of the next, the first and the last beyond it); then compound 2.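

In this assay, for the compounds shown here, the methyl now has a measured effect of its own: placing it on the aromatic carbon meta to a large group gives a 2.5-fold lower number from compound 3 to compound 4 (0.40 log units; beyond the scatter) and no earlier pair isolated this change. With the 3-methylphenyl group held fixed, isopropyl in place of methyl on the amide-type nitrogen gives a 1.6-fold lower number from compound 1 to compound 4 (0.21 log units; within the scatter) so the two compounds cannot be told apart at that place. No measurement at hand offers an explanation for either step.

The compounds shown leave open whether ethyl, methoxy or chlorine at the position of the methyl would move the number further. They also leave open what a cyclopropyl group or a longer chain on the amide-type nitrogen would do.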